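Moving a Nitrile Around a Ring with Toxicity in View

The source may report more compounds than this note shows. Statements on the series, on what has been measured and on what is new or still open speak of the compounds shown alone.

Three measured compounds and one unmeasured compound are compared in a toxicity assay on THP-1 cells (Homo sapiens) for inhibition; on this read-out higher numbers stand for lower toxicity in this test and lower numbers for higher toxicity in this test. Compound 1 `Cn1c(-c2cccc(C#N)c2)cnc1NC(=O)c1ncc[nH]1` gives in this assay > 50000 nM, which is a limit of the assay rather than a number. Compound 2 `COc1ccc(-c2cnc(NC(=O)c3cccc(C#N)c3)n2C)cc1` gives in this assay > 100000 nM, again a limit. Compound 3 `COc1ccc(-c2ccc(NC(=O)c3ccc(F)cc3)nc2)cc1` gives in this assay > 100000 nM, also a limit. Among the compounds with values here, compound 2 thus stands at the limit of > 100000 nM in this assay, at which 2 of the 3 values shown sit, while compound 1 sits at the limit of > 50000 nM in this assay, at which 1 of the 3 values shown sits; none of the three measured compounds shows a number for its toxicity, and no pair of them differs in only one place, so no measured step is available.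

Compound 4 `COc1ccc(-c2cnc(NC(=O)c3ccc(C#N)cc3)n2C)cc1` is the unmeasured compound. It differs from compound 2 in one place: 4-cyanophenyl in place of 3-cyanophenyl on a carbonyl carbon. Such a rearrangement is expected to leave the result in this assay within the usual scatter, in no particular direction, so the expected step is a number no higher from compound 2 to compound 4 (the limit leaves the size open). Compound 4 is therefore expected to give about 100000 nM in this assay, between 50000 nM and 200000 nM, and most likely to be reported again only as a limit.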

Compound 4, half-maximal cytotoxic concentration: > 100000 nM
Compound 4 gave a limit, no number (the forecaster's own chance of this, stated with the estimate: 85%); the middle value sits exactly at the limit.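

Within the data shown here, compound 2 and compound 4 both end at a limit of the assay rather than a number, so no step between them can be read. The compounds shown leave open whether 3-cyanophenyl and 4-cyanophenyl on the carbonyl carbon differ at all in this assay.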